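Exocyclic alkene linker with sulfur-containing ring on the pyridone series

A few compounds are considered here, and "the series" means these few. Any claim that something is new, unique, unknown or untested is made for them only; others in the source may bear on it.

Measured in an assay on membranes from Chem-1 cells for displacement of a labelled ligand from prostaglandin E2 receptor EP3 subtype (Homo sapiens), read by scintillation counting, with a stated time of 2 h; on this read-out lower numbers stand for stronger inhibition and higher numbers for weaker inhibition:
compound 1 `CC(C)C(CC1C(=O)NC(=O)N1C)c1ccc(-c2ccc3cccc(F)c3c2)[nH]c1=O`: 17 nM
compound 2 `O=C1NC(=O)/C(=C/C(c2ccc(-c3ccc4cccc(F)c4c3)[nH]c2=O)C2CCCCC2)O1`: 4 nM
compound 3 `CCC(/C=C1\OC(=O)NC1=O)(CC)c1ccc(-c2ccc3cccc(C(F)(F)F)c3c2)[nH]c1=O`: 230 nM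

Compound 1 stands second highest of the three numbers in this assay; compound 2 gives a lower number beyond the scatter, compound 3 a higher one well beyond it. Compound 4 `CC(C)C(/C=C1\SC(=O)NC1=O)c1ccc(-c2ccc3cccc(F)c3c2)[nH]c1=O` differs from compound 1 by a group of 8 heavy atoms (4 carbon, 1 nitrogen, 2 oxygen, 1 sulfur; one five-membered non-aromatic ring with 2 hetero atoms) in place of a group of 9 heavy atoms (5 carbon, 2 nitrogen, 2 oxygen; one five-membered non-aromatic ring with 2 hetero atoms), on a saturated chain carbon bound to an aromatic carbon and a saturated chain carbon. Within the data shown here, no measured pair isolates this exchange. Compound 2, which also carries an exocyclic double bond into a five-membered ring on the same core, gives 4 nM in this assay, so a moderate step toward a lower number is expected from compound 1 to compound 4, a 2.1-fold lower number from compound 1 to compound 4 (0.33 log units; beyond the scatter), though it may not exceed the scatter. For compound 4 the estimate in this assay is 8 nM (range 2 nM to 35 nM).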

Compound 4, inhibition constant: 13 nM
Compound 4: the middle estimate sits 1.6-fold (0.21 log units) below what was measured; the range from low to high includes it.
By their numbers in this assay, from the lowest: compound 2; then compounds 4 and 1 (each within the scatter of the next); then compound 3.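

In this assay, placing the sulfur-containing ring with its exocyclic double bond on the saturated chain carbon, in place of (3-methyl-2,5-dioxoimidazolidin-4-yl)methyl, gives a 1.3-fold lower number from compound 1 to compound 4 (0.12 log units; within the scatter). This position therefore takes either group with no readable difference on this read-out, even though the exchange alters both the ring and its link to the chain. No measured property bears on this result.

Among these compounds, the single step cannot separate the ring exchange from the double bond. Going by these compounds, how a carboxylic acid in place of the ring would read in this assay remains open.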